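Trimethoxyphenyl triazoles: aryl swap on the ring carbon

The source may report more compounds than this note shows. Statements on the series, on what has been measured and on what is new or still open speak of the compounds shown alone.

Compound 1 `COc1cccc(-c2ncnn2-c2cc(OC)c(OC)c(OC)c2)c1` carries a 3-methoxyphenyl group on the shared core. In a functional assay on HL-60 cells (Homo sapiens) for antiproliferative activity, read by MTT assay, with a stated time of 72 h (on this read-out lower numbers stand for stronger inhibition and higher numbers for weaker inhibition), compound 1 reaches only the assay limit, > 10000 nM, so no number stands for it. Compound 2 `COc1cc(-c2ncnn2-c2ccc(F)cc2)cc(OC)c1OC` likewise gives only the limit > 10000 nM in this assay. Compound 3 `COc1cc(-c2ncnn2-c2cccc([N+](=O)[O-])c2)cc(OC)c1OC` also stops at the limit > 10000 nM in this assay. For the measured compounds named here, all three values sit at the limit of > 10000 nM in this assay, at which 3 of the 3 values shown sit, so nothing measured separates the compounds so far. Compound 4 `COc1cc(-n2ncnc2-c2ccc(F)cc2)cc(OC)c1OC` is the unmeasured analogue. It differs from compound 1 by 4-fluorophenyl in place of 3-methoxyphenyl on an aromatic carbon. Every member so far sits at the limit. For compound 4 a step within the scatter is expected, a step that the limit leaves unreadable from compound 1 to compound 4, with the read-out most likely again a limit. Compound 4 is therefore estimated at 15000 nM, between 5000 nM and 50000 nM.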

Compound 4, half-maximal inhibitory concentration: > 10000 nM
Compound 4: no number, only a limit; the forecaster's own chance of this, stated with the estimate: 80%; the middle value does not contradict the limit.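

In this assay, for the compounds shown here, compound 4 stops at the limit > 10000 nM, so no step between compound 1 and compound 4 can be read: the limit of > 10000 nM in this assay, at which 4 of the 4 values shown sit. The compounds shown leave open whether any aryl swap on the shared core gives a measurable value.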